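A few compounds are considered here, and "the series" means these few. Any claim that something is new, unique, unknown or untested is made for them only; others in the source may bear on it.

Two measurements anchor this series. In a functional assay on SW480 cells (Homo sapiens) for inhibition, read by luminescence and resazurin assay, with a stated time of 3 days (a lower number here means a stronger inhibitor, a higher number a weaker inhibitor), compound 2 `CN(C)c1nc(NCc2ccc(NC(=O)c3ccncc3)cc2)c2ccccc2n1` gives 11000 nM, the higher of the two numbers and therefore the weaker inhibitor of the pair. Compound 1 `CN1CCN(c2nc(NCc3ccc(NC(=O)c4ccc(F)cc4)cc3)c3ccccc3n2)CC1`, in this assay, gives 2500 nM; the gap between the two lies beyond the scatter, but the two structures differ in more than one place, so no single change can be read from that gap.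

Compound 3 `CN1CCN(c2nc(NCc3ccc(NC(=O)c4ccncc4)cc3)c3ccccc3n2)CC1` is the untested follow-on from compound 2. The change is 4-methylpiperazin-1-yl in place of dimethylamino on an aromatic carbon, which carries over the ring amine found in compound 1 while keeping the amide of compound 2. With no single-point comparison available, the step from compound 2 to compound 3 is expected to be modest and toward a lower number, about a 2.2-fold lower number from compound 2 to compound 3 (0.34 log units; beyond the scatter). For compound 3 the estimate in this assay is 5000 nM, with a range of 1500 nM to 15000 nM.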

Compound 3, half-maximal inhibitory concentration: > 20000 nM
Compound 3: a limit, no number; the forecaster's own chance of this, stated with the estimate: 5%; middle value at least 4.0-fold (0.60 log units) from the limit.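

In this assay compound 3 gives > 20000 nM, a limit of the assay and not a number. Going by these compounds alone, on the aromatic carbon between two ring nitrogen atoms, 4-methylpiperazin-1-yl in place of dimethylamino gives an at least 1.8-fold higher number from compound 2 to compound 3 (0.25 log units; that floor lies within the scatter), so this change brings no gain in this pair, though the floor of that step stays within the scatter and the true size of the change cannot be read. Within the data shown here, with 4-methylpiperazin-1-yl held, pyridin-4-yl in place of 4-fluorophenyl on the carbonyl carbon gives an at least 8.0-fold higher number from compound 1 to compound 3 (0.90 log units; beyond the scatter), the first single-change reading, and it places the lower number of the pair with the 4-fluorophenyl amide.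

As far as these compounds go, whether that amide effect holds with dimethylamino on the aromatic carbon remains open. Also open, from the compounds shown here alone, is how a morpholin-4-yl group at that carbon, or an unsubstituted phenyl on the carbonyl, would read.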